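From methoxy to cyano on compound 1

The source may hold more compounds than are shown below. What is called first, only, known or untested is meant among the compounds shown, and "the series" means these compounds.

compound 1 `COc1ccc(/C=C2\CN(C)C/C(=C\c3ccccc3F)C2=O)cc1` - 23500 nM
compound 2 `COc1cc(/C=C2\CN(C)C/C(=C\c3ccccc3F)C2=O)cc(OC)c1OC` - 3220 nM
compound 3 `CN1C/C(=C\c2cccc([N+](=O)[O-])c2)C(=O)/C(=C/c2ccccc2F)C1` - 2340 nM

In a functional assay on HeLa cells (Homo sapiens) for cytotoxicity, read by MTT assay, with a stated time of 24 h (a higher number here means a weaker inhibitor, a lower number a stronger inhibitor), compound 1 stands highest of the three at 23500 nM, and the other two lie lower, beyond the scatter. Compound 4 `CN1C/C(=C\c2ccc(C#N)cc2)C(=O)/C(=C/c2ccccc2F)C1` remains unmeasured. It differs from compound 1 thus: cyano in place of methoxy on an aromatic carbon, with cyano in place of methoxy on an aromatic carbon. Among the compounds with values here, no measured pair differs in one place only, so the expectation rests on the values alone. Compound 3 has no methoxy group and gives 2340 nM, while compound 2 keeps methoxy groups and still gives 3220 nM. A lower number beyond the scatter is therefore expected, and the expected change is a 5.9-fold lower number from compound 1 to compound 4 (0.77 log units; beyond the scatter). For compound 4 the estimated value is 4000 nM, with an expected range of 1300 nM to 12000 nM.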

Compound 4, half-maximal inhibitory concentration: 1340 nM
Estimate against measurement, compound 4: 3.0-fold (0.47 log units) above; low and high end bracket the measured number.
By their numbers in this assay, from the lowest: compounds 4, 3 and 2 (each within the scatter of the next, the first and the last beyond it); then compound 1.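

In this assay, within the data shown here, the change from 4-methoxyphenyl to 4-cyanophenyl gives an 18-fold lower number from compound 1 to compound 4 (1.24 log units; beyond the scatter) and is the first step in which only one place differs. Among these compounds, it shows that this aromatic carbon, para to a large group, strongly affects the number, which the earlier compounds, differing in more than one place, could not isolate. Nothing available explains why the step is so large.

The compounds shown leave open whether methoxy raises the number or cyano lowers it, which a plain hydrogen at this carbon would help separate. As far as these compounds go, how an amine or a carboxylic acid would behave at this place also remains open.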